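From acetyl to ethoxycarbonyl: compound 3 toward compound 4

A few compounds are considered here, and "the series" means these few. Any claim that something is new, unique, unknown or untested is made for them only; others in the source may bear on it.

The series shares one core carrying two amide arms. Compound 1 `CCOC(=O)C(=O)Nc1nc2ccc(NC(=O)c3cc(Br)c[nH]3)cc2s1` gives 41300 nM in a functional assay on MCF7 cells (Homo sapiens) for antiproliferative activity; on this read-out higher numbers stand for an effect only at larger amounts of compound and lower numbers for an effect already at smaller amounts. Within the data shown here, compound 2 `CCOC(=O)C(=O)Nc1nc2ccc(NC(=O)c3cc4ccccc4[nH]3)cc2s1` gives 11200 nM in this assay, and the step of a 3.7-fold lower number from compound 1 to compound 2 (0.57 log units; beyond the scatter) is the only measured step so far. Compound 3 `CC(=O)C(=O)Nc1ccc2nc(NC(=O)c3cc4ccccc4[nH]3)sc2c1` returns only a limit in this assay, > 50000 nM, so its standing among the measured values is open at the weak end; the limit is the one described by the limit of > 50000 nM in this assay, at which 1 of the 3 values shown sits.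

Compound 4 `CCOC(=O)C(=O)Nc1ccc2nc(NC(=O)c3cc4ccccc4[nH]3)sc2c1` keeps the core of compound 3 and changes (ethoxy in place of methyl on a carbonyl carbon), in other words acetyl to ethoxycarbonyl on the (acetylcarbonyl)amino arm. Among the measured compounds shown here, no measured step touches this position: the step of a 3.7-fold lower number from compound 1 to compound 2 (0.57 log units; beyond the scatter) concerns the other amide arm, so it gives no direct reading for the size of the present change. For the measured compounds named here, compound 2 carries the same ethoxycarbonyl arm as compound 4, though on the other nitrogen of the core, and reaches a measurable number; this is the only hint that compound 4 could come off the limit. The expected step of an at least 1.2-fold lower number from compound 3 to compound 4 (0.09 log units; that floor lies within the scatter) is therefore set as a modest move toward lower numbers in this assay, with wide uncertainty. Compound 4 is estimated at 40000 nM in this assay, within 15000 nM to 120000 nM.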

Compound 4, half-maximal effective concentration: 8990 nM
Compound 4: middle estimate off by 4.4-fold (0.65 log units), on the high side; the whole stated range lies above it.
By their numbers in this assay, from the lowest: compounds 4 and 2 (each within the scatter of the next); then compound 1. At a limit, above all of these: compound 3.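

Among these compounds, the acetyl to ethoxycarbonyl change gives the first reading on the (acetylcarbonyl)amino arm, as the earlier measured step concerned the other amide arm. In this assay, ethoxy in place of methyl on a carbonyl carbon gives an at least 5.5-fold lower number from compound 3 to compound 4 (0.74 log units; beyond the scatter), so this position can carry a change in the read-out that lies beyond the scatter. The size of that step remains a floor and not a measured distance, because its starting point is a limit: the limit of > 50000 nM in this assay, at which 1 of the 4 values shown sits.

The compounds shown leave open whether the step follows the oxygen of the ethoxy group, the longer chain or both, since methyl and ethoxy differ in both respects and this single pair cannot separate them. An ethyl group, a methoxy group, a butoxy chain, an amine or a carboxylic acid on the same carbonyl carbon would show how far the read-out follows chain length and the atom attached there, and whether the ethoxycarbonyl arm keeps its effect with other groups on the other amide arm also remains unsettled.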